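Chloro in place of nitrile on compound 2

A few compounds are considered here, and "the series" means these few. Any claim that something is new, unique, unknown or untested is made for them only; others in the source may bear on it.

Compound 1 `N#Cc1ccc(NC(=O)c2ccc(Br)cc2O)c(Cl)c1`: 1860 nM
Compound 2 `N#Cc1cc(Cl)ccc1NC(=O)c1ccc2cccnc2c1O`: 280 nM
Compound 3 `O=C(Nc1cc(C(F)(F)F)cc(C(F)(F)F)c1)c1ccc(-c2ccccc2)cc1O`: 1580 nM

All three compounds were tested in a functional assay on NALM-6 cells (Homo sapiens) for cytotoxicity, read by luminescence and CellTiter-Glo, with a stated time of 3 days; on this read-out higher numbers stand for weaker inhibition and lower numbers for stronger inhibition. Compound 2 gives the lowest number of the three, and the gaps from it up to compound 1 and to compound 3 both lie beyond the usual scatter.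

Compound 4 `O=C(Nc1ccc(Cl)cc1Cl)c1ccc2cccnc2c1O`, not yet measured, keeps the core of compound 2 and alters one group: chloro in place of cyano on an aromatic carbon. The swap sits ortho to a large group and meta to a chloro group.

Within the data shown here, no measured pair isolates this swap, so the data give no direct size for it. Compound 1, which carries a nitrile, gives 1860 nM, while compound 3, which carries none, gives 1580 nM. Among these two, then, the nitrile does not go with a distinct number. In this assay no step beyond the scatter is therefore expected, only a slight rise in the number. The estimated change is a 1.3-fold higher number from compound 2 to compound 4 (0.10 log units; within the scatter). For compound 4 the expected value is 350 nM, with an estimated range from 120 nM to 1000 nM.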

Compound 4, half-maximal inhibitory concentration: 450 nM
Compound 4: the middle estimate sits 1.3-fold (0.11 log units) below what was measured; low and high end bracket the measured number.
By their numbers in this assay, from the lowest: compounds 2 and 4 (each within the scatter of the next); then compounds 3 and 1 (each within the scatter of the next).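

Chloro in place of cyano, on the aromatic carbon ortho to a large group and meta to a chloro group, now has a directly measured size: in this assay the swap gives a 1.6-fold higher number from compound 2 to compound 4 (0.21 log units; within the scatter). The earlier compounds shown here differed in several places and could not show this, whereas this single change shows that the nitrile is not required at this position to keep the number within the scatter of that of compound 2. A single chlorine atom, counted with no hydrogen-bond acceptor, can stand there in place of the two heavy atoms of the cyano group without a step beyond the scatter, and nothing measured here accounts for how the two groups come to read alike.

From the compounds shown here alone, what an amine, a carboxylic acid or a longer chain would do on the same aromatic carbon remains open, as does whether the swap would read the same way on a different core. The chloro group that stays in place in both compounds is also unvaried, so its own share in these numbers cannot be read.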